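The compounds below may be only part of what the source reports. "The series", "measured", "known", "first", "only" and "open" are said of these compounds alone.

Values in an assay on isolated protein for displacement of a labelled ligand from Motilin receptor (Homo sapiens); a lower number here means a stronger inhibitor, a higher number a weaker inhibitor:

compound 1 `CCC[C@@H]1NC(=O)[C@@H](C(C)C)NC(=O)[C@@H](CCC(=O)O)NCCOc2ccccc2/C=C/CNC1=O`: > 10000 nM.
compound 2 `CCC[C@@H]1NC(=O)[C@@H](C(C)C)NC(=O)[C@@H](Cc2ccccc2)NCCOc2ccccc2/C=C/CNC1=O`: 78 nM.
compound 3 `CCC[C@@H]1NC(=O)[C@@H](CCC(=O)O)NC(=O)[C@@H](Cc2ccc(O)cc2)NCCOc2ccccc2/C=C/CNC1=O`: 4900 nM.

Compound 1 shows not a number but a limit, namely (the limit of > 10000 nM in this assay, at which 1 of the 3 values shown sits). Among the two compounds with a number, compound 3 gives 4900 nM, the higher of the two; compound 2 gives 78 nM. Among the measured compounds shown here, no single-point step links compound 2 and compound 3, so only the two values themselves are noted.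

Compound 4 `CCC[C@@H]1NC(=O)[C@@H](Cc2ccccc2)NC(=O)[C@@H](Cc2ccc(O)cc2)NCCOc2ccccc2/C=C/CNC1=O` has not yet been measured. It differs from compound 3 in one place: phenyl in place of carboxymethyl on a saturated chain carbon bound to a saturated ring carbon. For the measured compounds named here, the one measured step that bears on this is the same exchange at the same place, where the number falls by an at least 120-fold lower number from compound 1 to compound 2 (2.10 log units; beyond the scatter); that step starts from a limit, so its true size is not pinned down beyond the stated minimum. Carrying the same change onto compound 3 is therefore expected to give a large drop, well beyond the scatter, in this assay, the estimated step being a 98-fold lower number from compound 3 to compound 4 (1.99 log units; beyond the scatter). For compound 4 the estimated value in this assay is 50 nM, with a range of 10 nM to 250 nM. The measured value follows.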

Compound 4, inhibition constant: 1520 nM
Compound 4: the middle estimate sits 30-fold (1.48 log units) below what was measured, outside the stated range (above it).
By their numbers in this assay, from the lowest: compound 2; then compound 4; then compound 3. At a limit, above all of these: compound 1.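

In this assay, the exchange of carboxymethyl for phenyl on a saturated chain carbon bound to a saturated ring carbon still lowers the number on the core of compound 3, but only modestly, with a 3.2-fold lower number from compound 3 to compound 4 (0.51 log units; beyond the scatter). The size of this exchange is therefore not a fixed increment that carries from one core to the other, and the two listed cores give clearly different steps: the same change on two cores in this assay, an at least 120-fold lower number (2.10 log units; beyond the scatter) from compound 1 to compound 2 and a 3.2-fold lower number (0.51 log units; beyond the scatter) from compound 3 to compound 4, at least 39-fold (1.59 log units) apart, beyond the scatter of two such steps. Compound 1 gives > 10000 nM, which is a limit and not a number, so the larger step and the gap between the two steps are known only as minimum values.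

From the compounds shown here alone, how an amine, a primary amide or an unbranched alkyl chain on this carbon would rank against phenyl and carboxymethyl in this assay remains open. Also open is which feature of the core sets the size of the step, as no pair of compounds shown here isolates that feature.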